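The source may hold more compounds than are shown below. What is called first, only, known or untested is meant among the compounds shown, and "the series" means these compounds.

Measured compounds:
- compound 1 `O=C(/C=C/c1cccc(NC(=O)c2ccccc2Br)c1)c1nc2ccccc2[nH]1`: 6050 nM
- compound 2 `O=C(Nc1cccc(/C=C/C(=O)c2nc3ccccc3[nH]2)c1)c1ccc(Br)cc1`: 7310 nM
- compound 3 `Cc1cccc(C(=O)Nc2cccc(/C=C/C(=O)c3nc4ccccc4[nH]3)c2)c1`: 4880 nM

All three share one core and differ only in the aromatic ring attached to the carbonyl carbon of the amide. In a functional assay on 143B cells (Homo sapiens) for antiproliferative activity, read by MTT assay, with a stated time of 48 h (a higher number here means a weaker inhibitor, a lower number a stronger inhibitor), compound 1 stands second highest of the three numbers; its nearest neighbour is compound 2, with a 1.2-fold higher number from compound 1 to compound 2 (0.08 log units; within the scatter), and its furthest is compound 3, with a 1.2-fold lower number from compound 1 to compound 3 (0.09 log units; within the scatter). The remaining pair, a 1.5-fold lower number from compound 2 to compound 3 (0.18 log units; within the scatter), is likewise within the scatter, so the three compounds are indistinguishable on these numbers.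

Compound 4 `Cc1ccccc1S(=O)(=O)Nc1cccc(/C=C/C(=O)c2nc3ccccc3[nH]2)c1` is not yet measured. It departs from compound 1 as follows: (2-methylphenyl)sulfonyl in place of (2-bromophenyl)carbonyl on a nitrogen on an aromatic ring. Two things change at once: the 2-methylphenyl ring and the sulfonyl in place of the carbonyl. The measured steps speak only to the first; swapping 2-bromophenyl for 4-bromophenyl or 3-methylphenyl moved nothing beyond the scatter. Within the data shown here, no measured step touches a sulfonyl, so that part of the change is uncharted. The working expectation in this assay is therefore a step of a 1.0-fold lower number from compound 1 to compound 4 (0.00 log units; within the scatter), that is, no change beyond the scatter, with a wider range than usual to allow for the unprobed sulfonyl. Compound 4 is estimated at 6000 nM, expected between 2500 nM and 15000 nM.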

Compound 4, half-maximal inhibitory concentration: 4060 nM
Beside the measured number, compound 4's estimate is 1.5-fold (0.17 log units) above it; the range from low to high includes it.
By their numbers in this assay, from the lowest: compounds 4, 3, 1 and 2 (each within the scatter of the next).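

On the nitrogen on an aromatic ring, the (2-methylphenyl)sulfonyl group stays within the scatter of all three amides in this assay (a 1.5-fold lower number from compound 1 to compound 4 (0.17 log units; within the scatter); a 1.2-fold lower number from compound 3 to compound 4 (0.08 log units; within the scatter); a 1.8-fold lower number from compound 2 to compound 4 (0.26 log units; within the scatter)). Compounds 1, 2 and 3 varied only the ring on the carbonyl carbon, whereas compound 4 shows that the linking carbonyl can also give way to a sulfonyl, together with a ring change, without a step beyond the scatter. No evidence on the cause of these numbers accompanies the series.

On these data alone, the sulfonyl and the ring change remain unseparated in compound 4, so the contribution of each is unknown. Also open, as far as these compounds go, is whether a carboxylic acid or an amine on the aromatic ring of this group would move the number beyond the scatter.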